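The compounds below may be only part of what the source reports. "The series", "measured", "known", "first", "only" and "open" are said of these compounds alone.

In an ADME assay on microsomes from liver (Homo sapiens) for metabolic stability (on this read-out lower numbers stand for slow clearance and higher numbers for fast clearance), compound 1 (`CCCC(Oc1ccc(-n2cc(C(=O)N(C)C)cn2)cc1)c1ccc(C(=O)NCCC(=O)O)cc1`) gives < 13 mL/min/kg as a limit. Compound 2 (`CCCC(Oc1ccc(-n2cc(C#N)cn2)cc1)c1ccc(C(=O)NCCC(=O)O)cc1`) gives < 8 mL/min/kg as a limit too. Compound 3 (`CCC(Oc1ccc(-n2cc(C(F)(F)F)cn2)cc1)c1ccc(C(=O)NCCC(=O)O)cc1`) stands at < 8 mL/min/kg as a limit as well, so it offers no exact number to build on. Compound 4 (`CC(C)CC(Oc1ccc(-n2cc(C(F)(F)F)cn2)cc1)c1ccc(C(=O)NCCC(=O)O)cc1`) differs from it by isopropyl in place of methyl on a saturated chain carbon, two bonds along the chain from an aromatic carbon and an oxygen on an aromatic ring with isopropyl in place of methyl on a saturated chain carbon, two bonds along the chain from an aromatic carbon and an oxygen on an aromatic ring. Among the measured compounds shown here, the only measured step is a step that the two limits leave unreadable from compound 1 to compound 2 and it concerns another group, so it lends no size to this change. Therefore a number no lower from compound 3 to compound 4 (the limit leaves the size open) is the estimated step in this assay and none beyond the scatter is expected. Compound 4 is expected at 8 mL/min/kg with 4 mL/min/kg and 16 mL/min/kg as the estimated ends of its range.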

Compound 4, clearance: 23 mL/min/kg
For compound 4 the middle estimate is 2.9-fold (0.46 log units) below the measured one, and the stated range ends below it.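

In this assay, isopropyl in place of methyl on a saturated chain carbon, two bonds along the chain from an aromatic carbon and an oxygen on an aromatic ring, gives an at least 2.8-fold higher number from compound 3 to compound 4 (0.45 log units; beyond the scatter), the only readable step among the compounds shown. Its true size stays open at the upper end because compound 3 rests on a limit: the limit of < 8 mL/min/kg in this assay, at which 2 of the 4 values shown sit.

The step from compound 1 to compound 2 cannot be read. On these data alone, it also remains open whether the branch or the added length in going from ethyl to isobutyl carries the step, a question that a straight butyl chain at this place would address.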